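Nitrofuranylmethyl piperazines: cytotoxicity with fluoro in place of methyl

A few compounds are considered here, and "the series" means these few. Any claim that something is new, unique, unknown or untested is made for them only; others in the source may bear on it.

Measured compounds:
- compound 1, `CC(C)(C)OC(=O)N1CCN(Cc2ccc([N+](=O)[O-])o2)CC1`: > 64000 nM
- compound 2, `Cc1ccc(S(=O)(=O)N2CCN(Cc3ccc([N+](=O)[O-])o3)CC2)cc1`: > 54000 nM

Both measured compounds share the nitrofuranylmethyl piperazine core and were tested in an ADME assay on HepG2 cells (Homo sapiens) for cytotoxicity, read by MTT assay, with a stated time of 24 h; on this read-out higher numbers stand for lower toxicity in this test and lower numbers for higher toxicity in this test. Compound 1 carries a tert-butoxycarbonyl group and in this assay reaches only a limit, > 64000 nM, which is the limit of > 64000 nM in this assay, at which 1 of the 2 values shown sits. Compound 2 carries a 4-methylphenylsulfonyl group and in this assay likewise gives only a limit, > 54000 nM, which is the limit of > 54000 nM in this assay, at which 1 of the 2 values shown sits. Thus compound 2 stands at a limit, and the one other value shown is a limit as well; neither compound gave a number in this assay.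

Compound 3, `O=[N+]([O-])c1ccc(CN2CCN(S(=O)(=O)c3ccc(F)cc3)CC2)o1`, is not yet measured. It differs from compound 2 by fluoro in place of methyl on an aromatic carbon. Within the data shown here, with no measured step between compound 2 and compound 3 and with both known values sitting at limits, the step from compound 2 to compound 3 is expected to be none beyond the scatter, and the most likely outcome is again a limit. The step that the limit leaves unreadable from compound 2 to compound 3 is the estimated change. For compound 3 in this assay the estimate is 60000 nM, within 30000 nM to 120000 nM.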

Compound 3, half-maximal cytotoxic concentration: > 54000 nM
Compound 3: no number, only a limit (the forecaster's own chance of this, stated with the estimate: 75%); the middle value is on the limit's open side.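

In this assay, compound 2 and compound 3 both end at a limit, and no step can be read between them: the limit of > 54000 nM in this assay, at which 2 of the 3 values shown sit.

The compounds shown leave open whether 4-methylphenyl and 4-fluorophenyl differ in cytotoxicity at all, and what half-maximal cytotoxic concentration compound 1, compound 2 or compound 3 would give as an actual number.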